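The source may report more compounds than this note shows. Statements on the series, on what has been measured and on what is new or still open speak of the compounds shown alone.

Measured in an ADME assay on L6 cells (Rattus norvegicus) for cytotoxicity, read by resazurin assay, with a stated time of 72 h; on this read-out lower numbers stand for stronger inhibition and higher numbers for weaker inhibition:
- Compound 1 `CCc1ccc(C(=O)NC(=O)c2ccccc2O)cc1`: 70 ug/mL
- Compound 2 `O=C(NC(=O)c1ccccc1O)c1ccc(-c2ccccc2)cc1`: > 100 ug/mL, a limit of the assay and not a number
- Compound 3 `CN(C)c1ccc(C(=O)NC(=O)c2ccccc2O)cc1`: 54 ug/mL

Only compound 1 and compound 3 have actual numbers. These two sit within the scatter of each other, with a 1.3-fold lower number from compound 1 to compound 3 (0.11 log units; within the scatter), so compound 3 stands level with compound 1.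

The next compound is compound 4 `Nc1ccc(C(=O)NC(=O)c2ccccc2O)cc1`, which keeps the shared core and changes one group: amino in place of dimethylamino on an aromatic carbon, para to a large group (amino in place of dimethylamino on an aromatic carbon). This exact swap has not been measured, but the three measured steps all exchange the group at this same place. Besides the step already given, there is an at least 1.4-fold higher number from compound 1 to compound 2 (0.15 log units; that floor lies within the scatter) and an at least 1.8-fold lower number from compound 2 to compound 3 (0.26 log units; that floor lies within the scatter). Both of these rest on the limit for compound 2, described as the limit of > 100 ug/mL in this assay, at which 1 of the 3 values shown sits, and the floor of each lies within the scatter. No swap at this place has therefore been shown to move the result in this assay beyond the scatter, and none is expected here.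

The expected change is a 1.1-fold higher number from compound 3 to compound 4 (0.05 log units; within the scatter), which would lie within the scatter. For compound 4 the estimated value is 60 ug/mL, with an expected range from 25 ug/mL to 100 ug/mL.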

Compound 4, half-maximal inhibitory concentration: 39 ug/mL
For compound 4 the middle estimate is 1.5-fold (0.19 log units) above the measured one; the measured number falls inside the stated range.
By their numbers in this assay, from the lowest: compounds 4, 3 and 1 (each within the scatter of the next). At a limit, above all of these: compound 2.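

In this assay, among the compounds shown here, this position now gives its first step beyond the scatter, the earlier steps having stayed within it or having a floor within it: amino in place of phenyl gives an at least 2.5-fold lower number from compound 2 to compound 4 (0.40 log units; beyond the scatter). The other two steps to compound 4 do not separate it from its neighbours, with amino in place of dimethylamino giving a 1.4-fold lower number from compound 3 to compound 4 (0.14 log units; within the scatter) and amino in place of ethyl giving a 1.8-fold lower number from compound 1 to compound 4 (0.25 log units; within the scatter), so removing the two carbons of dimethylamino shows no clear effect on the result. The step from compound 2 gives only a minimum size, since compound 2 has a limit and not a number: the limit of > 100 ug/mL in this assay, at which 1 of the 4 values shown sits.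

Going by these compounds, how far compound 2 really lies from compound 4 stays unknown, and these few groups cannot show whether the hydrogen-bond donor that amino brings plays any part in the result. A methylamino group, a hydroxyl group, a carboxylic acid or a longer chain at this place could help to settle whether only phenyl stands apart from the other groups, or whether the result follows some wider trend.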